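The source may hold more compounds than are shown below. What is called first, only, known or untested is meant among the compounds shown, and "the series" means these compounds.

Measured compounds in a functional assay on A549 cells (Homo sapiens) for cytotoxicity, read by MTT assay, with a stated time of 24 h, tested at 10 uM; on this read-out lower numbers stand for a stronger effect and higher numbers for a weaker effect at the one concentration tested:
- compound 1, `CCCCCCCCOC(=O)CCC(=O)N1CCN(CCCOc2cc3c(Nc4ccc(F)c(Cl)c4)ncnc3cc2OC)CC1`, gives 87.3%
- compound 2, `CCCCCCCCCOC(=O)CCC(=O)N1CCN(CCCOc2cc3c(Nc4ccc(F)c(Cl)c4)ncnc3cc2OC)CC1`, gives 90%
- compound 3, `CCCCCCCCCCCCCCCCOC(=O)CCC(=O)N1CCN(CCCOc2cc3c(Nc4ccc(F)c(Cl)c4)ncnc3cc2OC)CC1`, gives 97.7%

The three share one core and differ only in the length of the saturated chain on the ester oxygen. Compound 1 to compound 2 is methyl in place of hydrogen on a saturated chain carbon, eight bonds along the chain from an oxygen next to a carbonyl group; the step is a number 2.7 percentage points higher from compound 1 to compound 2 (within the scatter). Compound 1 to compound 3 is octyl in place of hydrogen on a saturated chain carbon, eight bonds along the chain from an oxygen next to a carbonyl group, and the step is a number 10.4 percentage points higher from compound 1 to compound 3 (beyond the scatter). Between compound 2 and compound 3 the step is a number 7.7 percentage points higher from compound 2 to compound 3 (within the scatter).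

Compound 4, `CCCCCCCCCCCCCCCCCOC(=O)CCC(=O)N1CCN(CCCOc2cc3c(Nc4ccc(F)c(Cl)c4)ncnc3cc2OC)CC1`, is not yet measured. From compound 3 it is methyl in place of hydrogen on a saturated chain carbon, ten or more bonds along the chain from an oxygen next to a carbonyl group. This is the same kind of change as from compound 1 to compound 2, but at a different place on the chain, as the two descriptions of the differences show. The cores of compound 1 and compound 3 differ as given by octyl in place of hydrogen on a saturated chain carbon, eight bonds along the chain from an oxygen next to a carbonyl group.

The expected step from compound 3 to compound 4 is a number 1.3 percentage points higher from compound 3 to compound 4 (within the scatter), because a number 2.7 percentage points higher from compound 1 to compound 2 (within the scatter) for the same kind of change was within the scatter. Compound 4 is estimated at 99% in this assay, from 90% to 106%.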

Compound 4, a percentage reported as activity, at one concentration (the size of the read-out at that concentration, not a potency): 95.7%
The estimate for compound 4 lay 3.3 percentage points above the measured number, and the stated range covers the measured number.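

In this assay, for the compounds shown here, methyl in place of hydrogen on the chain of compound 3 gives a number 2 percentage points lower from compound 3 to compound 4 (within the scatter), while the longer additions give a number 5.7 percentage points higher from compound 2 to compound 4 (within the scatter) and a number 8.4 percentage points higher from compound 1 to compound 4 (within the scatter), so no step to compound 4 lies beyond the scatter. The methyl change carries from one core to the other with no difference beyond the scatter, although it stands at a different place on the chain in each pair: the same change on two cores in this assay, a number 2.7 percentage points higher (within the scatter) from compound 1 to compound 2 and a number 2 percentage points lower (within the scatter) from compound 3 to compound 4, 4.7 percentage points apart, within the scatter of two such steps. Steps this small show only that the two pairs agree, not that the change has a consistent effect of its own on any other core, and the octyl pair agrees to the same degree even though only one of its steps lies beyond the scatter: the same change on two cores in this assay, a number 10.4 percentage points higher (beyond the scatter) from compound 1 to compound 3 and a number 5.7 percentage points higher (within the scatter) from compound 2 to compound 4, 4.7 percentage points apart, within the scatter of two such steps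

The compounds shown leave open whether a chain shorter than that of compound 1 would give a lower number in this assay. Also open, on these data alone, is what a branched chain, or a chain ending in an amine or a carboxylic acid, would give on the shared core.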